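One More Methoxy Group on Two Different Cores

The source may hold more compounds than are shown below. What is called first, only, known or untested is meant among the compounds shown, and "the series" means these compounds.

Compound 1 `COc1ccc(/C=C/C(=O)c2ccccc2-c2cccc(F)c2)cc1` is tested in a functional assay on CNE-2 cells (Homo sapiens) for antiproliferative activity, read by sulforhodamine B assay, with a stated time of 48 h (a lower number here means a stronger inhibitor, a higher number a weaker inhibitor), where compound 1 gives 73 nM. Compound 2 `COc1ccc(/C=C/C(=O)c2ccccc2-c2cccc(F)c2)cc1OC` differs from it by methoxy in place of hydrogen on an aromatic carbon; in this assay compound 2 gives 650 nM, so the change produced an 8.9-fold higher number from compound 1 to compound 2 (0.95 log units; beyond the scatter). Compound 3 `COc1ccc(CNC(=O)c2ccccc2-c2ccc(F)cc2)cc1OC` is built on a different core, and the difference between the two cores is not broken down here. In this assay compound 3 reaches only a limit of the assay, > 50000 nM. That limit is the limit of > 50000 nM in this assay, at which 1 of the 3 values shown sits. Compound 4 `COc1cc(CNC(=O)c2ccccc2-c2ccc(F)cc2)cc(OC)c1OC` differs from compound 3 by methoxy in place of hydrogen on an aromatic carbon. The surroundings are not word for word the same as in the first pair, since here the new group is also meta to a methoxy group, so this is the same kind of change rather than the same change. Among the compounds with values here, the only measured example of it weakened the compound, and no example shows it helping. For compound 4 the expected step is therefore a step that the limit leaves unreadable from compound 3 to compound 4, resting on that earlier step and on the starting point of compound 3 at a limit. Compound 4 is expected to give 100000 nM in this assay, with a range from 30000 nM to 500000 nM, most likely reported again only as a limit.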

Compound 4, half-maximal inhibitory concentration: > 50000 nM
Compound 4 was reported as a limit (the forecaster's own chance of this, stated with the estimate: 85%); the middle value is on the limit's open side.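

Compound 4 gives > 50000 nM in this assay and this is a limit of the assay, not a number. Within the data shown here, compound 3 also stands only as a limit, so no step from compound 3 to compound 4 can be read: the limit of > 50000 nM in this assay, at which 2 of the 4 values shown sit. The compounds shown leave open whether the added methoxy group changes activity at all on this core.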